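Loss of a 3-Methylbut-2-en-1-yl Group in Two Parallel Cases

The source may report more compounds than this note shows. Statements on the series, on what has been measured and on what is new or still open speak of the compounds shown alone.

Compound 1 `COc1cc(OC)c(C(=O)/C=C/c2ccc(OC)c(OC)c2)c(OCC=C(C)C)c1` and compound 2 `COc1ccc(/C=C/C(=O)c2c(OCC=C(C)C)cc(OC)c(CC=C(C)C)c2OC)cc1OC` were both tested in a functional assay on HCT-116 cells (Homo sapiens) for antiproliferative activity, read by sulforhodamine B assay, with a stated time of 48 h; a higher number here means a weaker inhibitor, a lower number a stronger inhibitor; compound 1 gives 5700 nM and compound 2 gives 7400 nM. The change hydrogen in place of 3-methylbut-2-en-1-yl on an aromatic carbon made a step of a 1.3-fold lower number from compound 2 to compound 1 (0.11 log units; within the scatter). Compound 3 `COc1cccc(/C=C/C(=O)c2c(O)c(CC=C(C)C)c(OC)c(CC=C(C)C)c2OC)c1OC` gives 15300 nM in this assay, the highest of the three numbers; the difference between its core and that of compound 2 is not broken down here. Compound 4 `COc1cc(O)c(C(=O)/C=C/c2cccc(OC)c2OC)c(OC)c1CC=C(C)C` awaits measurement. It differs from compound 3 by hydrogen in place of 3-methylbut-2-en-1-yl on an aromatic carbon, the same kind of change as before, though here the carbon is ortho to a hydroxy group and a methoxy group, meta to a 3-methylbut-2-en-1-yl group and para to a methoxy group, rather than ortho to two methoxy groups and para to a (3-methylbut-2-en-1-yl)oxy group. Because the earlier step of a 1.3-fold lower number from compound 2 to compound 1 (0.11 log units; within the scatter) stayed within the scatter, compound 4 is expected to show a step of a 1.3-fold lower number from compound 3 to compound 4 (0.11 log units; within the scatter). Compound 4 is estimated at 12000 nM, with a range from 5000 nM to 30000 nM.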

Compound 4, half-maximal inhibitory concentration: 29500 nM
For compound 4 the middle estimate is 2.5-fold (0.39 log units) below the measured one; measured number inside the range.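

Putting hydrogen in place of the 3-methylbut-2-en-1-yl group on an aromatic carbon of the core of compound 3 gave a 1.9-fold higher number from compound 3 to compound 4 (0.29 log units; within the scatter) in this assay and so moved the number no further than repeated measurements might. Set beside the earlier case, the two steps cannot be told apart: the same change on two cores in this assay, a 1.3-fold lower number (0.11 log units; within the scatter) from compound 2 to compound 1 and a 1.9-fold higher number (0.29 log units; within the scatter) from compound 3 to compound 4, 2.5-fold (0.40 log units) apart, within the scatter of two such steps. In these two pairs the change thus carried from one core to the other without a distinct result, but two pairs show neither a rule for the series nor that the step would stay this small on any further core.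

The compounds shown leave open what an amine, a carboxylic acid or a longer chain on that aromatic carbon would do. They also leave open how the same change would read in any test other than this assay.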